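Swapping the aryl ketone of a naphthyl sulfonamide series

This account rests on a few compounds, and the source may have more. Where it says the series, first, only, none or still open, it means among the compounds named here.

Measured so far in an ADME assay on C8166 cells (Homo sapiens) for cytotoxicity, read by colorimetric assay and MTT assay; a lower number here means that less compound is tolerated, a higher number that more compound is tolerated:
- compound 1 `Cc1ccc(C(=O)c2c(OCC(=O)Nc3ccc(S(N)(=O)=O)cc3C)ccc3ccccc23)c(C)c1` gives 25500 nM
- compound 2 `Cc1cc(S(N)(=O)=O)ccc1NC(=O)COc1ccc2cc(Br)ccc2c1C(=O)c1cccc(Cl)c1` gives 6800 nM
- compound 3 `Cc1cc(S(N)(=O)=O)ccc1NC(=O)COc1ccc2cc(Br)ccc2c1C(=O)c1cccc(F)c1` gives 31000 nM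

Compound 3 has the highest number of the three, though its gap to compound 1 is within the scatter; only compound 2 sits clearly lower. Compound 4 `Cc1ccc(C(=O)c2c(OCC(=O)Nc3ccc(S(N)(=O)=O)cc3C)ccc3cc(Br)ccc23)c(C)c1` is not yet measured; it differs from compound 3 by 2,4-dimethylphenyl in place of 3-fluorophenyl on a carbonyl carbon. For the measured compounds named here, one measured step bears on this position: a 4.6-fold higher number from compound 2 to compound 3 (0.66 log units; beyond the scatter), a modest change. Compound 1 carries the same 2,4-dimethylphenyl and gives a number close to compound 3, so a step within or just beyond the scatter is expected, a 1.6-fold lower number from compound 3 to compound 4 (0.19 log units; within the scatter), with no firm direction. Compound 4 is therefore estimated at 20000 nM, within 7000 nM to 45000 nM.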

Compound 4, half-maximal cytotoxic concentration: 61400 nM
Compound 4: the middle estimate sits 3.1-fold (0.49 log units) below what was measured; measured number above the stated range.
By their numbers in this assay, from the lowest: compound 2; then compounds 1, 3 and 4 (each within the scatter of the next, the first and the last beyond it).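

In this assay, 2,4-dimethylphenyl in place of 3-fluorophenyl on the carbonyl carbon gives a 2.0-fold higher number from compound 3 to compound 4 (0.30 log units; within the scatter) and so cannot be told apart from it, while the same group in place of 3-chlorophenyl gives a 9.0-fold higher number from compound 2 to compound 4 (0.96 log units; beyond the scatter) in the same series. Bromo in place of hydrogen on an aromatic carbon gives a 2.4-fold higher number from compound 1 to compound 4 (0.38 log units; beyond the scatter) and shows, with 2,4-dimethylphenyl held fixed, that this second site also shifts the number. No measurement here explains either shift. Still open, on these data alone, is how an aryl ketone carrying an amine or a carboxylic acid would behave, and whether chloro or methoxy in place of bromo would give a similar shift.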